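A few compounds are considered here, and "the series" means these few. Any claim that something is new, unique, unknown or untested is made for them only; others in the source may bear on it.

Measured compounds:
compound 1 `O=C(CN(c1nc(Cl)nc2[nH]cnc12)C1CC1)NCC(=O)OCc1ccccc1`: 18%
compound 2 `CC[C@H](C)[C@H](NC(=O)CN(c1nc(Cl)nc2[nH]cnc12)C1CC1)C(=O)O`: 6.71%

Both were tested in a functional assay on the whole organism (Tail, strain ICR) with Mus musculus as the target, in the tail flick test, with a stated time of 150 min, at a dose of 25 umol/kg by the oral route; on this read-out lower numbers stand for a weaker effect and higher numbers for a stronger effect at the one dose given. Compound 1 gives 18%, the higher of the two numbers shown, while compound 2 gives 6.71%, a reading lower by an amount beyond the scatter. Compound 3 `O=C(CN(c1nc(Cl)nc2[nH]cnc12)C1CC1)N[C@@H](CCC(=O)OCc1ccccc1)C(=O)OCc1ccccc1` has not yet been measured in this assay. It differs from compound 1 in one place: 2-(benzyloxycarbonyl)ethyl in place of hydrogen on a saturated chain carbon bound to an amide-type nitrogen and a carbonyl carbon. The shared core and the cyclopropyl group are kept, and the new group enters on a saturated chain carbon bound to an amide-type nitrogen and a carbonyl carbon. Among the compounds with values here, no measured pair shows this exact change, so the effect can only be guessed from how far apart compound 1 and compound 2 lie. The step from compound 1 to compound 3 is expected to be small, a number 4 percentage points lower from compound 1 to compound 3 (within the scatter), and not clearly beyond the scatter. Compound 3 is therefore estimated at 14%, within a range from 3% to 30%.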

Compound 3, a percentage reported as activity, at one dose (the size of the read-out at that dose, not a potency): 44.5%
Compound 3: the middle estimate sits 30.5 percentage points below what was measured; the whole stated range lies below it.
By their numbers in this assay, from the lowest: compound 2; then compound 1; then compound 3.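

In this assay the saturated chain carbon bound to an amide-type nitrogen and a carbonyl carbon can carry far more than hydrogen: adding 2-(benzyloxycarbonyl)ethyl, a group of 12 heavy atoms, gives a number 26.5 percentage points higher from compound 1 to compound 3 (beyond the scatter) at the one dose tested. The added group therefore goes with a stronger effect here, not a loss of effect. The data offered give no explanation for this rise.

Going by these compounds, with a single change at this position, it remains open whether the whole 2-(benzyloxycarbonyl)ethyl group matters or only part of it, such as its benzyl ester or its six-membered aromatic ring. A free carboxylic acid at the end of the chain, an amine there or a shorter chain would help separate these possibilities.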